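Replacing 1-benzothiophen-2-yl with phenylsulfonyl: a step beyond the limit

The compounds below may be only part of what the source reports. "The series", "measured", "known", "first", "only" and "open" are said of these compounds alone.

In an ADME assay on cells (Fibroblast, Gallus gallus) for cytotoxicity, read by CCK-8 assay, with a stated time of 48 h (on this read-out higher numbers stand for lower toxicity in this test and lower numbers for higher toxicity in this test), compound 3 (`CCC(CC)O[C@@H]1C=C(C(=O)O)C[C@H](NCc2ccc(-c3cc4ccccc4s3)cc2)[C@H]1NC(C)=O`) gives > 200000 nM, which is a limit and not a number. Compound 1 (`CCc1ccc(CN[C@H]2CC(C(=O)O)=C[C@@H](OC(CC)CC)[C@@H]2NC(C)=O)cc1`) also gives only a limit, > 200000 nM. Compound 2 (`CCC(CC)O[C@@H]1C=C(C(=O)O)C[C@H](NCc2ccc(Sc3cccs3)cc2)[C@H]1NC(C)=O`) likewise gives only a limit, > 200000 nM. The evidence therefore comes down to the limit of > 200000 nM in this assay, at which 3 of the 3 values shown sit.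

Compound 4 (`CCC(CC)O[C@@H]1C=C(C(=O)O)C[C@H](NCc2ccc(S(=O)(=O)c3ccccc3)cc2)[C@H]1NC(C)=O`) departs from compound 3 at one place: phenylsulfonyl in place of 1-benzothiophen-2-yl on an aromatic carbon. The measured changes at that same aromatic carbon are a step that the two limits leave unreadable from compound 1 to compound 2, a step that the two limits leave unreadable from compound 1 to compound 3 and a step that the two limits leave unreadable from compound 2 to compound 3. None of these has a size that can be carried over, although ethyl, (thiophen-2-yl)sulfanyl and 1-benzothiophen-2-yl all end at the limit in compounds 1, 2 and 3.

No change beyond the usual scatter is expected in this assay, and the estimated size is a step that the limit leaves unreadable from compound 3 to compound 4. Compound 4 is expected at an estimated 250000 nM, within an expected range from 100000 nM to 500000 nM.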

Compound 4, half-maximal cytotoxic concentration: > 200000 nM
Compound 4 ended at the assay's limit (the forecaster's own chance of this, stated with the estimate: 85%); the middle value is on the limit's open side.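

Compound 4 gives only a limit in this assay, as do compound 1, compound 2 and compound 3, so no step among these four compounds can be read: the limit of > 200000 nM in this assay, at which 4 of the 4 values shown sit.

The compounds shown leave open whether any group on that aromatic carbon would give a measured number instead of a limit.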